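The source may report more compounds than this note shows. Statements on the series, on what has been measured and on what is new or still open speak of the compounds shown alone.

Series notes. Compound 1 `COC(=O)c1cc(-c2cnc(C(=O)CCc3ccc(-c4ccccc4)cc3)o2)ccn1` gives 1.5 nM in an assay for inhibition of Fatty-acid amide hydrolase 1 (Rattus norvegicus); a higher number here means a weaker inhibitor, a lower number a stronger inhibitor; compound 2 `N#Cc1cccc(-c2cnc(C(=O)CCc3ccc(-c4ccccc4)cc3)o2)n1` gives 2.9 nM; compound 3 `O=C(CCc1ccc(-c2ccccc2)cc1)c1ncc(-c2cccc(-c3nnn[nH]3)n2)o1` gives 25 nM. Compound 2 holds the second highest of the three numbers: the step of a 1.9-fold higher number from compound 1 to compound 2 (0.29 log units; within the scatter) lies within the scatter, whereas an 8.6-fold higher number from compound 2 to compound 3 (0.94 log units; beyond the scatter) lies beyond it. Compound 4 `NC(=O)c1ccc(-c2cnc(C(=O)CCc3ccc(-c4ccccc4)cc3)o2)nc1` is not yet measured. Its change from compound 2: 5-carbamoylpyridin-2-yl in place of 6-cyanopyridin-2-yl on an aromatic carbon. Going by the values given here, the only step that bears on it is the replacement of cyano on the same carrier, an 8.6-fold higher number from compound 2 to compound 3 (0.94 log units; beyond the scatter), a modest weakening. The carbamoyl group is closer in size to cyano than the tetrazole was, so a smaller weakening is expected in this assay. Compound 4 is expected at 8 nM, between 2.5 nM and 30 nM. The estimate corresponds to an expected step of a 2.8-fold higher number from compound 2 to compound 4 (0.44 log units; beyond the scatter).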

Compound 4, inhibition constant: 1.3 nM
Estimate against measurement, compound 4: 6.2-fold (0.79 log units) above; measured number outside the range, below it.
By their numbers in this assay, from the lowest: compounds 4, 1 and 2 (each within the scatter of the next, the first and the last beyond it); then compound 3.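

At this position on the shared core, an aromatic carbon next to the ring oxygen, a pyridine with a group bearing a hydrogen-bond donor need not cost affinity: 5-carbamoylpyridin-2-yl in place of 6-cyanopyridin-2-yl gives a step in the other direction from the tetrazole (a 2.2-fold lower number from compound 2 to compound 4 (0.35 log units; beyond the scatter)). In this assay, 5-carbamoylpyridin-2-yl and 2-(methoxycarbonyl)pyridin-4-yl cannot be told apart (a 1.2-fold lower number from compound 1 to compound 4 (0.06 log units; within the scatter)). Nothing available explains the step. Going by these compounds, whether the carbamoyl group itself or its place on the pyridine carries this step stays open. So does whether a carboxylic acid or a methylamide there would hold the same level.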